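The compounds below may be only part of what the source reports. "The series", "measured", "known", "first", "only" and "open" are said of these compounds alone.

Compound 1 `O=C1N=C(N2CCC[C@H]2C(=O)Nc2ccc3ncnc(Nc4cccc(Cl)c4)c3c2)S/C1=C/c1cccc(Cl)c1`; in a functional assay on A549 cells (Homo sapiens) for antiproliferative activity, read by MTT assay (on this read-out lower numbers stand for stronger inhibition and higher numbers for weaker inhibition), compound 1 gives > 50000 nM, a limit of the assay.
Compound 2 `O=C1N=C(N2CCC[C@H]2C(=O)Nc2ccc3ncnc(Nc4cccc(Cl)c4)c3c2)S/C1=C/c1cccnc1`; in this assay compound 2 gives 10400 nM.
Compound 3 `O=C1N=C(N2CCC[C@H]2C(=O)Nc2ccc3ncnc(Nc4cccc(Cl)c4)c3c2)S/C1=C/c1ccccc1Br`; in this assay compound 3 gives > 50000 nM, a limit of the assay.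

Compound 2 holds the only number shown; the other two values are limits (the limit of > 50000 nM in this assay, at which 2 of the 3 values shown sit). Compound 4 `O=C1N=C(N2CCC[C@H]2C(=O)Nc2ccc3ncnc(Nc4cccc(Cl)c4)c3c2)S/C1=C/c1ccc2ccccc2n1` differs from compound 2 in one place: quinolin-2-yl in place of pyridin-3-yl on a double-bonded chain carbon bound to a double-bonded ring carbon. Among the measured compounds shown here, the steps that bear on it are the changes at the same place, an at least 4.8-fold lower number from compound 1 to compound 2 (0.68 log units; beyond the scatter) and an at least 4.8-fold higher number from compound 2 to compound 3 (0.68 log units; beyond the scatter); both carbocyclic aryl groups gave limits, and only the pyridin-3-yl gave a number. The quinolin-2-yl carries more heavy atoms, so a higher number is expected, possibly again a limit: a 2.9-fold higher number from compound 2 to compound 4 (0.46 log units; beyond the scatter). Compound 4 is estimated at 30000 nM, between 8000 nM and 100000 nM.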

Compound 4, half-maximal inhibitory concentration: > 50000 nM
Compound 4 was reported as a limit (the forecaster's own chance of this, stated with the estimate: 50%); middle value at least 1.6-fold (0.22 log units) away from the limit.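

Quinolin-2-yl also carries a ring nitrogen, yet the change gives an at least 4.8-fold higher number from compound 2 to compound 4 (0.68 log units; beyond the scatter), so a ring with a hetero atom on the double-bonded chain carbon does not by itself yield a number. The steps among compound 1, compound 3 and compound 4 cannot be read. Compound 2 still holds the only number, and the other values are limits: the limit of > 50000 nM in this assay, at which 3 of the 4 values shown sit.

Open, from the compounds shown here alone, is whether pyridin-4-yl, or a phenyl carrying an amine or a carboxylic acid, would give a number at this place.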